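Adding a Hydroxy Group to Compound 2

The source may report more compounds than this note shows. Statements on the series, on what has been measured and on what is new or still open speak of the compounds shown alone.

compound 1 `O=C1c2c(O)cc(O)cc2O[C@@H](c2cc(O)ccc2O)[C@@H]1O`: 25400 nM in a physicochemical assay, read by spectrophotometry, with a stated time of 30 min; a lower number here means that less compound is needed, a higher number that more compound is needed for the effect
compound 2 `O=C1c2c(O)cc(O)cc2O[C@H](c2cccc(O)c2)[C@H]1O`: > 100000 nM in this assay

Compound 2 stands at a limit of this assay, (the limit of > 100000 nM in this assay, at which 1 of the 2 values shown sits), so no number is known for it. Compound 1 gives 25400 nM in this assay. Compound 3 (`O=C1c2c(O)cc(O)cc2O[C@H](c2cc(O)ccc2O)[C@H]1O`) differs from compound 2 by hydroxy in place of hydrogen on an aromatic carbon. In this assay a step toward a lower number is expected, beyond the scatter, though the limit for compound 2 leaves its size open. Compound 3 is estimated at 40000 nM, between 15000 nM and 150000 nM, a step of an at least 2.5-fold lower number from compound 2 to compound 3 (0.39 log units; beyond the scatter).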

Compound 3, half-maximal effective concentration: 24500 nM
Compound 3: middle estimate off by 1.6-fold (0.21 log units), on the high side; measured number inside the range.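

In this assay hydroxy in place of hydrogen on this aromatic carbon, ortho to a large group and para to a hydroxy group, gives an at least 4.0-fold lower number from compound 2 to compound 3 (0.61 log units; beyond the scatter) and this size is only a bound: the limit of > 100000 nM in this assay, at which 1 of the 3 values shown sits. With both stereocentres inverted, the result is a 1.0-fold lower number from compound 1 to compound 3 (0.02 log units; within the scatter) and so the two compounds carrying this hydroxy group do not separate in this assay: the fact that compounds 1 and 3 differ only in the configuration as drawn.

On these data alone, the true size of the step from compound 2 remains open. So does whether another group at this place, such as an amine or a methoxy group, would give a similar number.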